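Two Measured Compounds and One Unmeasured Change

This account rests on a few compounds, and the source may have more. Where it says the series, first, only, none or still open, it means among the compounds named here.

Compound 2, whose structure is `CCC(C)[C@H](N)c1cc(C(F)(F)F)ccc1N1CCN(C(=O)CCc2ccc(Cl)cc2)CC1`, was tested in an assay on HEK293 cells for displacement of a labelled ligand from Melanocortin receptor 4 (Homo sapiens) (a higher number here means a weaker inhibitor, a lower number a stronger inhibitor), where compound 2 gives 86 nM. That is the lower of the two numbers recorded. The other measured compound is compound 1, with the structure `NC(COCc1ccccc1)c1cc(F)ccc1N1CCN(C(=O)CCc2ccc(Cl)cc2Cl)CC1`; in this assay compound 1 gives 1000 nM. Compound 1 and compound 2 differ in more than one place, so their two values can only be set side by side: the number for compound 2 is the lower one, and the gap between them is beyond the scatter.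

Compound 3 has the structure `CCC(C)[C@H](N)c1cc(C(F)(F)F)ccc1N1CCN(C(=O)CCc2ccc(OC)c(OC)c2Cl)CC1`. It differs from compound 2 in one place: 2-chloro-3,4-dimethoxyphenyl in place of 4-chlorophenyl on a saturated chain carbon, two bonds along the chain from a carbonyl carbon. Going by the values given here, the chlorine on this ring moves and two methoxy groups enter; no measured pair shows a change of this kind, so the expectation rests on compound 2 alone. A small weakening of binding is expected, possibly within the scatter, as a 1.7-fold higher number from compound 2 to compound 3 (0.24 log units; within the scatter). The estimate for compound 3 in this assay is 150 nM, expected to lie between 40 nM and 600 nM.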

Compound 3, inhibition constant: 2500 nM
For compound 3 the middle estimate is 17-fold (1.22 log units) below the measured one; measured number outside the range, above it.
By their numbers in this assay, from the lowest: compound 2; then compound 1; then compound 3.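

In this assay, swapping 4-chlorophenyl for 2-chloro-3,4-dimethoxyphenyl gives a 29-fold higher number from compound 2 to compound 3 (1.46 log units; beyond the scatter), a large loss of binding from a single change. Going by these compounds alone, this is the first pair that differs in only one place, so this gap, unlike the one between compound 1 and compound 2, can be tied to one part of the molecule: the aromatic ring on a saturated chain carbon, two bonds along the chain from a carbonyl carbon. The result shows that binding is highly sensitive to what this ring carries, although no available measurement explains the loss.

The swap moves the chlorine and adds two methoxy groups in a single step, so the pair cannot show which of these changes accounts for the loss, or whether it takes both together. A phenyl ring carrying only the chlorine of compound 3, and another carrying only its two methoxy groups, would pull these changes apart, and a ring with a single methoxy group would show how much of the loss one such group brings.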